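Replacing 2-bromophenyl with 3-methoxyphenyl in compound 3

The source may hold more compounds than are shown below. What is called first, only, known or untested is meant among the compounds shown, and "the series" means these compounds.

Values measured in a functional assay on MCF7 cells (Homo sapiens) for cytotoxicity, read by MTT assay, with a stated time of 72 h (a lower number here means a stronger inhibitor, a higher number a weaker inhibitor), are as follows
Compound 1 `COc1cccc(/C=C2\CCC/C(=C\c3ccc(Cl)cc3)C2=O)c1OC` gives 10300 nM
Compound 2 `COc1cc(/C=C2\CCC/C(=C\c3cccc(OC)c3OC)C2=O)ccc1O` gives 11600 nM
Compound 3 `COc1ccc(/C=C2\CCC/C(=C\c3ccccc3Br)C2=O)cc1OC` gives 9500 nM

Compound 3 stands within the scatter of both compound 1 and compound 2, so the three values do not separate. Compound 4 `COc1cccc(/C=C2\CCC/C(=C\c3ccc(OC)c(OC)c3)C2=O)c1` has not yet been measured. Reaching it from compound 3 means 3-methoxyphenyl in place of 2-bromophenyl on a double-bonded chain carbon bound to a double-bonded ring carbon and this puts 3-methoxyphenyl in place of 2-bromophenyl on a double-bonded chain carbon bound to a double-bonded ring carbon. For the measured compounds named here, the one measured step that bears on this is a 1.1-fold higher number from compound 1 to compound 2 (0.05 log units; within the scatter) and it exchanged one substituted phenyl group for another at that same place. The expected step is a 1.1-fold higher number from compound 3 to compound 4 (0.02 log units; within the scatter) and none beyond the scatter is anticipated. In this assay compound 4 is estimated at 10000 nM with an expected range from 4500 nM to 20000 nM for now.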

Compound 4, half-maximal inhibitory concentration: 4600 nM
Compound 4: the middle estimate sits 2.2-fold (0.34 log units) above what was measured; the range from low to high includes it.
By their numbers in this assay, from the lowest: compound 4; then compounds 3, 1 and 2 (each within the scatter of the next).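

In this assay, the place on a double-bonded chain carbon bound to a double-bonded ring carbon now shows a step beyond the scatter (a 2.1-fold lower number from compound 3 to compound 4 (0.31 log units; beyond the scatter)), whereas the earlier exchange there stayed within it (a 1.1-fold higher number from compound 1 to compound 2 (0.05 log units; within the scatter)). Exchanging one substituted phenyl group for another at this place can therefore shift the read-out, if only modestly. No evidence is available to explain this shift.

As far as these compounds go, whether the lower number follows from 3-methoxyphenyl entering or from 2-bromophenyl leaving remains open. So does how a phenyl group carrying an amine or a carboxylic acid would behave at this place.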